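Removing a Chloro Group Next to Nothing Measured Before

The compounds below may be only part of what the source reports. "The series", "measured", "known", "first", "only" and "open" are said of these compounds alone.

Compound 1 `O=C(Nc1cccc(-n2cc(-c3ccncc3)c(-c3ccc(Cl)c(O)c3)n2)c1)Nc1ccc(Cl)c(Cl)c1` gives 1090 nM in a functional assay on SNB-75 cells (Homo sapiens) for inhibition, read by sulforhodamine B assay, with a stated time of 48 h; on this read-out higher numbers stand for weaker inhibition of growth and lower numbers for stronger inhibition of growth.
Compound 2 `COc1cc(-c2nn(-c3cccc(NC(=O)c4ccc(Cl)c(C(F)(F)F)c4)c3)cc2-c2ccncc2)ccc1Cl` gives 2190 nM in this assay.

Of the two measured compounds, compound 2 has the higher number, but its gap to compound 1 lies within the scatter, so the two cannot be ranked against each other. Compound 3 `COc1cc(-c2nn(-c3cccc(NC(=O)c4cccc(C(F)(F)F)c4)c3)cc2-c2ccncc2)ccc1Cl` has not been measured and differs from compound 2 in one place: hydrogen in place of chloro on an aromatic carbon. The chloro leaves an aromatic carbon of a six-membered aromatic ring of carbon only, a carbon that is ortho to a trifluoromethyl group and para to a large group; cut one bond further out, the difference reads 4-chloro-3-(trifluoromethyl)phenyl to 3-(trifluoromethyl)phenyl. Among the measured compounds shown here, no pair of measured compounds shows this change, so its effect in this assay is unknown. Because compound 2 gives 2190 nM and only a single heavy atom is removed, the step of a 1.4-fold higher number from compound 2 to compound 3 (0.14 log units; within the scatter) is expected to be small, probably toward a higher number, and possibly none beyond the scatter. Compound 3 is therefore estimated at 3000 nM, with a range from 1000 nM to 9000 nM in this assay.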

Compound 3, concentration for 50% growth inhibition: 1130 nM
Beside the measured number, compound 3's estimate is 2.7-fold (0.42 log units) above it; the measured number falls inside the stated range.
By their numbers in this assay, from the lowest: compounds 1, 3 and 2 (each within the scatter of the next).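

In this assay there is now a measured pair for this position, and it gives a 1.9-fold lower number from compound 2 to compound 3 (0.29 log units; within the scatter) when chloro gives way to hydrogen. Removing the chloro from this aromatic carbon, ortho to a trifluoromethyl group and para to a large group, therefore has no effect that can be told apart from the ordinary variation between repeated measurements. For this pair, 3-(trifluoromethyl)phenyl and 4-chloro-3-(trifluoromethyl)phenyl cannot be ranked on growth inhibition, so the chloro shows no measurable contribution here. Nothing available explains why this step is so small.

A single pair cannot show whether this carbon accepts other groups equally well, and a nitrile, an amine or a longer chain in the chloro's place could still give a number clearly apart from those of compound 2 and compound 3. On these data alone, it also remains open whether the same removal would give an equally small step on a different scaffold, such as the core of compound 1, where the rest of the molecule differs in several places.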